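Benzyloxy in Place of a Fluorophenyl Ring

The source may report more compounds than this note shows. Statements on the series, on what has been measured and on what is new or still open speak of the compounds shown alone.

Compound 2 `Cc1nc2cc(-c3ccc(-c4ccc(F)cc4)c(C#N)c3)ccc2s1` carries a 4-fluorophenyl group on the ring that bears the nitrile. In an in vitro functional assay on HEK293-A cells for antagonist activity at metabotropic glutamate receptor 5 (Rattus norvegicus), read by fluorescence and calcium flux, with a stated time of 140 s (a higher number here means a weaker inhibitor, a lower number a stronger inhibitor), compound 2 gives only a limit, > 10000 nM, not a number. That is where compound 2 stands among the values shown: it sits at the limit of > 10000 nM in this assay, at which 1 of the 3 values shown sits, and one further entry carries no number at all. That entry belongs to compound 1 `Cc1nc2cc(-c3cccc(C#N)c3)ccc2s1`, for which this assay reports "not determined" (no result reported). Compound 3 `COCOc1ccc(-c2ccc3ccc(C)nc3c2)cc1C#N`, built on a different core and bearing a methoxymethoxy group instead, gives 294 nM in this assay.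

Compound 4 `Cc1nc2cc(-c3ccc(OCc4ccccc4)c(C#N)c3)ccc2s1` differs from compound 2 in one place: benzyloxy in place of 4-fluorophenyl on an aromatic carbon. Within the data shown here, no step between two measured compounds is known here, so the size of this change cannot be read from a measured pair. Compound 3 does give a number, 294 nM, with an oxygen-linked group in the corresponding place, yet on another core, so it offers no more than a hint. Because compound 2 sits at the limit of > 10000 nM in this assay, at which 1 of the 3 values shown sits, any reported number for compound 4 would mean movement toward stronger inhibition, and the step from compound 2 to compound 4 is expected to be an at least 4.0-fold lower number from compound 2 to compound 4 (0.60 log units; beyond the scatter). Compound 4 is estimated at 2500 nM, within a range from 400 nM to 10000 nM.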

Compound 4, half-maximal inhibitory concentration: > 10000 nM
Compound 4 was reported as a limit; the forecaster's own chance of this, stated with the estimate: 35%; middle value at least 4.0-fold (0.60 log units) away from the limit.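

Among these compounds, both compound 2 and compound 4 give only a limit in this assay, so no step between them can be read, and both stand at the same value: the limit of > 10000 nM in this assay, at which 2 of the 4 values shown sit. The compounds shown leave open which of 4-fluorophenyl and benzyloxy gives the stronger inhibitor on their shared core, and by how much.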